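Methyl for trifluoromethyl: a repeated change in the series

The source may report more compounds than this note shows. Statements on the series, on what has been measured and on what is new or still open speak of the compounds shown alone.

Of the compounds shown here, three have been measured in a functional assay on HeLa cells (Homo sapiens) for inhibition, read by MTT assay, with a stated time of 72 h; on this read-out lower numbers stand for stronger inhibition and higher numbers for weaker inhibition. Compound 3 `CN(C(=O)NC(=O)c1c(F)cccc1F)c1nc(C(F)(F)F)c(C(=O)N/N=C/c2ccccc2C(F)(F)F)s1` gives 19.6 ug/mL and compound 1 `Cc1nc(N(C)C(=O)NC(=O)c2c(F)cccc2F)sc1C(=O)N/N=C/c1ccccc1C(F)(F)F` gives 6.51 ug/mL; the two differ by methyl in place of trifluoromethyl on an aromatic carbon and the step is a 3.0-fold lower number from compound 3 to compound 1 (0.48 log units; beyond the scatter). Compound 2 `CN(C(=O)NC(=O)c1c(F)cccc1F)c1nc(C(F)(F)F)c(C(=O)N/N=C/c2ccc(C(F)(F)F)cc2)s1` gives 30.6 ug/mL. It differs from compound 3 by 4-(trifluoromethyl)phenyl in place of 2-(trifluoromethyl)phenyl on a carbon with a double bond to nitrogen, and the step of a 1.6-fold lower number from compound 2 to compound 3 (0.19 log units; within the scatter) does not separate these two values.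

Compound 4 `Cc1nc(N(C)C(=O)NC(=O)c2c(F)cccc2F)sc1C(=O)N/N=C/c1ccc(C(F)(F)F)cc1` has not been measured. It differs from compound 2 by methyl in place of trifluoromethyl on an aromatic carbon. This is the same change as the one from compound 3 to compound 1: the group that leaves, the group that enters and the surroundings of the place are described in the same words for both pairs, and the two pairs are set apart only by the way the cores of compound 3 and compound 2 are joined, as described above. The change occurs twice among these four compounds and has one measured step.

The expectation for compound 4 in this assay rests on that single step. Compound 4 is expected to show a step of a 3.0-fold lower number from compound 2 to compound 4 (0.48 log units; beyond the scatter), matching the size of a 3.0-fold lower number from compound 3 to compound 1 (0.48 log units; beyond the scatter). The size is carried over without correction because the difference between the cores gave only a 1.6-fold lower number from compound 2 to compound 3 (0.19 log units; within the scatter), within the scatter, though the range is kept wide for a change with one supporting pair. The estimate for compound 4 is 10.2 ug/mL, between 5 ug/mL and 21 ug/mL.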

Compound 4, half-maximal inhibitory concentration: 40.6 ug/mL
Beside the measured number, compound 4's estimate is 4.0-fold (0.60 log units) below it, outside the stated range (above it).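

In this assay, methyl in place of trifluoromethyl on the aromatic carbon does not behave as a portable change: with 4-(trifluoromethyl)phenyl on the carbon with a double bond to nitrogen it gives a 1.3-fold higher number from compound 2 to compound 4 (0.12 log units; within the scatter), and this differs from the step seen with 2-(trifluoromethyl)phenyl: the same change on two cores in this assay, a 3.0-fold lower number (0.48 log units; beyond the scatter) from compound 3 to compound 1 and a 1.3-fold higher number (0.12 log units; within the scatter) from compound 2 to compound 4, 4.0-fold (0.60 log units) apart, beyond the scatter of two such steps. Read the other way, the exchange of the two trifluoromethylphenyl groups also depends on the group at the aromatic carbon, with a 6.2-fold higher number from compound 1 to compound 4 (0.79 log units; beyond the scatter) in the methyl compounds, against a step within the scatter in the trifluoromethyl compounds: the same change on two cores in this assay, a 1.6-fold lower number (0.19 log units; within the scatter) from compound 2 to compound 3 and a 6.2-fold lower number (0.79 log units; beyond the scatter) from compound 4 to compound 1, 4.0-fold (0.60 log units) apart, beyond the scatter of two such steps. Among these compounds, the two changes are therefore not additive across compound 1, compound 2, compound 3 and compound 4, but this single set of four shows only that the step size depends on the partner group, not what lies behind that dependence or whether it extends to any other compound.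

As far as these compounds go, whether the same dependence appears with an ethyl group, a chlorine or an amine on the aromatic carbon remains open. Also open, from the compounds shown here alone, is whether the low number of compound 1 needs 2-(trifluoromethyl)phenyl specifically, or would also appear with an unsubstituted phenyl or a 2-chlorophenyl on the carbon with a double bond to nitrogen.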